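Swapping the Ester Tail: Expected Cytotoxicity of Compound 3

The source may report more compounds than this note shows. Statements on the series, on what has been measured and on what is new or still open speak of the compounds shown alone.

Measured so far:
Compound 1 `C=CCn1c(=O)c(CCO)c(-c2ccccc2Cl)c2cc(Cl)ccc21`: 23000 nM
Compound 2 `CCOCC(=O)OCCc1c(-c2ccccc2Cl)c2cc(Cl)ccc2[nH]c1=O`: 130000 nM

In an ADME assay on HepG2 2.2.15 cells (Homo sapiens) for cytotoxicity (on this read-out higher numbers stand for lower toxicity in this test and lower numbers for higher toxicity in this test), compound 2 stands highest of the two numbers; the nearest, compound 1, gives 23000 nM, a gap beyond the usual scatter. Compound 3 `O=C(CN1C(=O)c2ccccc2C1=O)OCCc1c(-c2ccccc2Cl)c2cc(Cl)ccc2[nH]c1=O` is not yet measured. It differs from compound 2 in one place: a group of 11 heavy atoms (8 carbon, 1 nitrogen, 2 oxygen; one five-membered non-aromatic ring with 1 hetero atom, one six-membered aromatic ring of carbon only) in place of a group of 3 heavy atoms (2 carbon, 1 oxygen; no ring), on a saturated chain carbon bound to a carbonyl carbon. Among the compounds with values here, no measured pair shows what such a change does in this assay, so any expectation rests on compound 2 alone. A modest step toward a lower number is expected, a 1.6-fold lower number from compound 2 to compound 3 (0.21 log units; within the scatter), close to the scatter. Compound 3 is therefore estimated at 80000 nM, between 25000 nM and 200000 nM.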

Compound 3, half-maximal cytotoxic concentration: 960000 nM
Estimate against measurement, compound 3: 12-fold (1.08 log units) below; the whole stated range lies below it.
By their numbers in this assay, from the lowest: compound 1; then compound 2; then compound 3.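

In this assay, the group on the saturated chain carbon bound to a carbonyl carbon clearly counts: replacing ethoxy with the larger group carrying two rings gives a 7.4-fold higher number from compound 2 to compound 3 (0.87 log units; beyond the scatter). At this position, then, a much bigger group moves the number toward lower toxicity in this test, not higher. Nothing available explains this rise.

Still open, from the compounds shown here alone, is whether the rings themselves matter or simply the size of the group. A longer chain without rings, or an amine at the same place, would help separate the two.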